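A few compounds are considered here, and "the series" means these few. Any claim that something is new, unique, unknown or untested is made for them only; others in the source may bear on it.

In a functional assay on A549 cells (Homo sapiens) for antiproliferative activity, read by MTT assay, with a stated time of 48 h (on this read-out lower numbers stand for stronger inhibition and higher numbers for weaker inhibition), compound 1 (`CCCCCC1(O)C(=O)Nc2ccc(Nc3ccc(F)cc3)cc21`) gives 5900 nM, compound 3 (`O=C1Nc2ccc(Nc3ccc(F)cc3)cc2C1(O)Cc1ccccc1`) gives 3000 nM, and compound 2 (`CCCCCCC1(O)C(=O)Nc2ccc(Nc3ccc(F)cc3)cc21`) gives 12000 nM, the highest of the three numbers. Compound 4 (`CCCCCCC1(O)C(=O)Nc2ccc(Nc3ccc(Cl)cc3)cc21`) differs from compound 2 in one place: chloro in place of fluoro on an aromatic carbon. Going by the values given here, no measured step touches this halogen. All three change the chain instead: a 2.0-fold higher number from compound 1 to compound 2 (0.31 log units; beyond the scatter) and a 4.0-fold lower number from compound 2 to compound 3 (0.60 log units; beyond the scatter) are modest, while a 2.0-fold lower number from compound 1 to compound 3 (0.29 log units; within the scatter) stays within the scatter. Among the compounds with values here, with no direct precedent, the expected change is a 1.3-fold lower number from compound 2 to compound 4 (0.12 log units; within the scatter), a step not expected to exceed the scatter. For compound 4 the estimated value is 9000 nM, with an expected range from 4000 nM to 20000 nM.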

Compound 4, half-maximal inhibitory concentration: 5400 nM
Beside the measured number, compound 4's estimate is 1.7-fold (0.22 log units) above it; measured number inside the range.
By their numbers in this assay, from the lowest: compounds 3, 4 and 1 (each within the scatter of the next); then compound 2.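

Going by these compounds alone, this is the first change at the halogen rather than the chain, and it shows that the position on the aromatic ring para to a large group is not indifferent in this assay. With the chain of compound 2 kept, chloro in place of fluoro gives a 2.2-fold lower number from compound 2 to compound 4 (0.35 log units; beyond the scatter) and so a modest step beyond the scatter. Nothing available here accounts for this step.

From the compounds shown here alone, whether bromo or methoxy at this position would shift the number remains open. So does whether chloro gives a similar step on the chains of compound 1 and compound 3.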